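The source may hold more compounds than are shown below. What is called first, only, known or untested is meant among the compounds shown, and "the series" means these compounds.

Compounds measured so far:
compound 1, `CN(CCNCc1cn(-c2ccc(Br)cc2)nn1)CCNc1ccnc2cc(Cl)ccc12`, with 11000 nM;
compound 2, `CN(CCNCc1cn(Cc2ccccc2)nn1)CCNc1ccnc2cc(Cl)ccc12`, with 16000 nM.

Both were tested in a functional assay on HCC827 cells (Homo sapiens) for antiproliferative activity, read by sulforhodamine B assay, with a stated time of 72 h; on this read-out higher numbers stand for weaker inhibition and lower numbers for stronger inhibition. On these two numbers compound 2 gives the higher value, but the gap to compound 1 is small: a 1.5-fold higher number from compound 1 to compound 2 (0.16 log units; within the scatter). Among the compounds with values here, that single step, swapping one group on the aromatic nitrogen for another, therefore tells only that the change left the number where it was.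

Compound 3, `CN(CCNCc1cn(Cc2nc3ccccc3[nH]2)nn1)CCNc1ccnc2cc(Cl)ccc12`, has not yet been measured. It differs from compound 2 in one place: 1H-benzimidazol-2-yl in place of phenyl on a saturated chain carbon bound to an aromatic nitrogen. Within the data shown here, the only comparable step, the one from compound 1 to compound 2, was within the scatter, so the expectation for this assay is no step beyond the scatter, in either direction, with the new donor and acceptor leaving no clear trace in the data at hand. Compound 3 is thus expected to give about 14000 nM, in a range from 5000 nM to 40000 nM, an estimated step of a 1.1-fold lower number from compound 2 to compound 3 (0.06 log units; within the scatter).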

Compound 3, half-maximal inhibitory concentration: 164000 nM
For compound 3 the middle estimate is 12-fold (1.07 log units) below the measured one; measured number above the stated range.
By their numbers in this assay, from the lowest: compounds 1 and 2 (each within the scatter of the next); then compound 3.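

In this assay the group on this saturated chain carbon bound to an aromatic nitrogen clearly matters: replacing phenyl with 1H-benzimidazol-2-yl gives a 10-fold higher number from compound 2 to compound 3 (1.01 log units; beyond the scatter) and so weakens inhibition, unlike the earlier swap, which stayed within the scatter. Changing the whole 4-bromophenyl group to (1H-benzimidazol-2-yl)methyl gives a 15-fold higher number from compound 1 to compound 3 (1.17 log units; beyond the scatter) in the same direction, so the loss does not depend on which of the two earlier compounds serves as the reference. No measurement at hand says why the number rises.

The compounds shown cannot separate the larger ring system from its added hydrogen-bond donor and acceptor as the source of this loss. Going by these compounds, how an amine or a carboxylic acid in place of the ring would read also remains open.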